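Inverting one stereocentre at the cytotoxicity limit

This account rests on a few compounds, and the source may have more. Where it says the series, first, only, none or still open, it means among the compounds named here.

In a functional assay on A 172 cells (Homo sapiens) for cytotoxicity, read by MTT assay, with a stated time of 24 h (a lower number here means a stronger inhibitor, a higher number a weaker inhibitor), compound 1 (`CC(=O)O[C@@]1(C)C/C=C2\O[C@H](C[C@@H]2C)C[C@]2(C)O[C@H]2C(=O)C(=C(C)C)CC1`) gives > 50000 nM as a limit and not a number.

In this assay compound 2 (`CC(C)=C1CC[C@]2(C)CC[C@]3(O[C@H](C[C@H]3C)C[C@]3(C)O[C@H]3C1=O)O2`) gives > 50000 nM as a limit too. Compound 2 therefore stands at the limit of > 50000 nM in this assay, at which 2 of the 2 values shown sit, and has no number to rank it.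

Compound 3 (`CC(C)=C1CC[C@]2(C)CC[C@]3(O[C@H](C[C@@H]3C)C[C@]3(C)O[C@H]3C1=O)O2`) differs from compound 2 in configuration only: the two compounds have the same atoms and bonds and differ only in configuration as drawn: 1 of 6 stereo elements differ; a stereocentre at a saturated ring carbon is drawn R in compound 2 and S in compound 3 with a stereocentre at a saturated ring carbon drawn R in compound 2 and S in compound 3.

The expected size of a number no higher from compound 2 to compound 3 (the limit leaves the size open) stays within the scatter in this assay with no direction favoured.

Compound 3 is estimated at 50000 nM with an expected range of 25000 nM to 100000 nM and may again appear only as a limit.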

Compound 3, half-maximal inhibitory concentration: > 50000 nM
Compound 3: only a limit was reported; the forecaster's own chance of this, stated with the estimate: 80%; the middle value lies on the limit itself.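

No step can be read between compound 2 and compound 3: each stands only as a limit in this assay. The compounds shown leave open whether the configuration at this saturated ring carbon affects cytotoxicity at all.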